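A Larger Group on the Carbonyl Carbon of Compound 2

The compounds below may be only part of what the source reports. "The series", "measured", "known", "first", "only" and "open" are said of these compounds alone.

Compound 1 `CCCOC(=O)c1c(C)coc1-c1ccc2c(CC)cccc2c1OC` gives only a limit in a functional assay on ZR-75-1 cells (Homo sapiens) for cytotoxicity, read by MTT assay, with a stated time of 72 h (a higher number here means that more compound is needed for the effect, a lower number that less compound is needed), namely > 10 ug/mL.
Compound 2 `CCc1cccc2c(OC)c(-c3occ(C)c3C(=O)NC)ccc12` likewise gives only a limit in this assay, > 10 ug/mL.

Compound 2 therefore stands at the edge of what this assay reports, a point it shares with compound 1, since both values sit at the limit of > 10 ug/mL in this assay, at which 2 of the 2 values shown sit. Within the data shown here, the one measured step, a step that the two limits leave unreadable from compound 1 to compound 2, is the only change so far on the carbonyl carbon, and it cannot be read.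

Compound 3 `CCc1cccc2c(OC)c(-c3occ(C)c3C(=O)On3nnc4ccccc43)ccc12` differs from compound 2 by a group of 10 heavy atoms (6 carbon, 3 nitrogen, 1 oxygen; one five-membered aromatic ring with 3 hetero atoms, one six-membered aromatic ring of carbon only) in place of a group of 2 heavy atoms (1 carbon, 1 nitrogen; no ring), on a carbonyl carbon. No readable step bears on this change, so the expectation for compound 3 in this assay rests on the two limits alone, and the most that is expected is a move of a step that the limit leaves unreadable from compound 2 to compound 3, without a firm direction. Compound 3 is therefore estimated at 12 ug/mL, with a range from 3 ug/mL to 50 ug/mL, and a limit is the likelier report.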

Compound 3, concentration for half-maximal effect: > 10 ug/mL
Compound 3 was reported as a limit; the forecaster's own chance of this, stated with the estimate: 60%; the middle value lies beyond the limit too.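

Compound 3 also gives only a limit in this assay, > 10 ug/mL. The steps to compound 3 from compound 1 and from compound 2 therefore cannot be read: the limit of > 10 ug/mL in this assay, at which 3 of the 3 values shown sit.

The compounds shown leave open how far compound 1, compound 2 and compound 3 each lie beyond that limit, and whether the group on the carbonyl carbon affects the value in this assay at all.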